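The compounds below may be only part of what the source reports. "The series", "measured", "known", "first", "only" and "open" are said of these compounds alone.

Of the compounds shown here, three have been tested so far in a functional assay on ECa-109 cells for inhibition, with ECa-109 cell line (Homo sapiens) as the target, read by sulforhodamine B assay (a lower number here means a stronger inhibitor, a higher number a weaker inhibitor), and only one of them gives an actual number. Compound 2 `O=C1C(Nc2ccccc2)=CC(=O)c2c1nc1n2[C@H]2OC[C@@H](O)[C@H]2OC1` gives 3560 nM as that single number. Compound 1 `CCCc1ccc(NC2=CC(=O)c3nc4n(c3C2=O)[C@H]2OC[C@@H](O)[C@H]2OC4)cc1` sits at > 4000 nM as a limit of the assay. Compound 3 `O=C1C=C(N2CCC2)C(=O)c2c1nc1n2[C@H]2OC[C@@H](O)[C@H]2OC1` sits at > 16000 nM as a limit too. Compound 4 `Cc1ccc(NC2=CC(=O)c3c(nc4n3[C@H]3OC[C@@H](O)[C@H]3OC4)C2=O)cc1` comes from compound 2 through methyl in place of hydrogen on an aromatic carbon in the form of methyl in place of hydrogen on an aromatic carbon, para to a large group. Among the measured compounds shown here, no measured pair shows this change, so no shift beyond the usual scatter is expected in this assay here. Expected for the change is a 1.0-fold lower number from compound 2 to compound 4 (0.01 log units; within the scatter) and no more. Compound 4 is estimated at 3500 nM with an expected range from 1600 nM to 8000 nM in this read-out.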

Compound 4, half-maximal inhibitory concentration: > 4000 nM
Compound 4 was reported as a limit (the forecaster's own chance of this, stated with the estimate: 30%); at least 1.1-fold (0.05 log units) between middle value and limit.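

In this assay, methyl in place of hydrogen on an aromatic carbon, para to a large group, gives an at least 1.1-fold higher number from compound 2 to compound 4 (0.05 log units; that floor lies within the scatter), so this change brings no lower number. Compound 4 gives > 4000 nM, which is a limit of the assay, so the step is a floor only. Its true size cannot be read, and this limit is shared with another value: the limit of > 4000 nM in this assay, at which 2 of the 4 values shown sit.

Still open, going by these compounds, is how a chlorine, a methoxy or a carboxylic acid at this same place would read against compound 2 at 3560 nM. The compounds shown also leave open how far the number of compound 4 lies from the limit.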